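A few compounds are considered here, and "the series" means these few. Any claim that something is new, unique, unknown or untested is made for them only; others in the source may bear on it.

Series notes. Compound 1 `CCn1ncnc1-c1ccccc1NCC1=NCCN1` carries an ethyl on its core and compound 3 `Cn1ncnc1-c1ccccc1NCC1=NCCN1` a methyl on the same core; compound 2 `CC(C)n1nccc1-c1ccccc1NCC1=NCCN1` has an isopropyl on a second core, and compound 4 `CCn1nccc1-c1ccccc1NCC1=NCCN1` an ethyl on the core of compound 2. In a functional assay with Alpha-1B adrenergic receptor (Homo sapiens) as the target, read by calcium flux (a lower number here means a smaller maximal response, a higher number a larger maximal response), compound 1 gives 94%, compound 3 gives 93% and compound 2 gives 0%. The change hydrogen in place of methyl on a saturated chain carbon bound to an aromatic nitrogen brought a number 1 percentage points lower from compound 1 to compound 3 (within the scatter). The same kind of change, (hydrogen in place of methyl on a saturated chain carbon bound to an aromatic nitrogen and a saturated chain carbon), leads to compound 4; around the place, the carbon is here additionally bound to a saturated chain carbon. How the core of compound 2 differs from the core of compound 1 is not broken down here. For compound 4 a step of a number 15 percentage points higher from compound 2 to compound 4 (beyond the scatter) is expected, resting on a number 1 percentage points lower from compound 1 to compound 3 (within the scatter) and on compound 2 sitting at 0%. Compound 4 is expected to reach 15%, estimated between 0% and 60%.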

Compound 4, largest response reached (reported as maximal response), in percent of the reference or control that the assay uses: 0%
For compound 4 the middle estimate is 15 percentage points above the measured one, and the stated range covers the measured number.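

On the core of compound 2, isopropyl to ethyl gives in this assay no change at the digits printed from compound 2 to compound 4 (within the scatter). Set beside the matching step on the core of compound 1, the change carries over without a visible difference: the same change on two cores in this assay, a number 1 percentage points lower (within the scatter) from compound 1 to compound 3 and no change at the digits printed (within the scatter) from compound 2 to compound 4, 1 percentage points apart, within the scatter of two such steps. This rests on one pair per core, and since compound 2 gives 0% and compound 4 gives 0%, the second pair has no response to shift, so it does not show that the change would stay as small on a core with a measurable response at both ends.

Open remains how a longer chain such as butyl, or an amine, would read at this place on either core. Also open, as far as these compounds go, is whether isopropyl on the core of compound 1 would keep the response of compound 1.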